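The source may hold more compounds than are shown below. What is called first, only, known or untested is meant among the compounds shown, and "the series" means these compounds.

Compound 1 `COc1ccccc1N1CCN(CCCNc2ncccc2C(=O)N(C)C)CC1`: 1.59 nM
Compound 2 `COc1ccccc1N1CCN(CCCNc2ncccc2C(=O)C2CC2)CC1`: 0.501 nM
Compound 3 `COc1ccccc1N1CCN(CCCNc2nc(C)cc(C)c2C(N)=O)CC1`: 10 nM

In a functional assay for antagonist activity at Alpha-1A adrenergic receptor (Oryctolagus cuniculus) (a lower number here means tighter binding, a higher number weaker binding), compound 1 sits second highest of the three numbers shown. For the measured compounds named here, its nearest neighbour is compound 2, which gives 0.501 nM; the only single-point step among the measured compounds is a 3.2-fold lower number from compound 1 to compound 2 (0.50 log units; beyond the scatter), a change at the carbonyl carbon. The remaining compound differs from compound 1 in more than one place; compound 3 gives the highest number of the set at 10 nM.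

Compound 4 `COc1cc(C)ccc1N1CCN(CCCNc2ncccc2C(=O)N(C)C)CC1` is the next step from compound 1. The change is methyl in place of hydrogen on an aromatic carbon. Going by the values given here, no measured step touches this ring, so the step from compound 1 to compound 2 offers no guide to it, and nothing in the set speaks for a move beyond the scatter in this assay. Compound 4 is therefore expected to give 1.6 nM, between 0.6 nM and 4.5 nM, which means an expected step of a 1.0-fold higher number from compound 1 to compound 4 (0.00 log units; within the scatter).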

Compound 4, dissociation constant: 0.794 nM
The estimate for compound 4 lay 2.0-fold (0.30 log units) above the measured number, within the range that was stated.
By their numbers in this assay, from the lowest: compounds 2, 4 and 1 (each within the scatter of the next, the first and the last beyond it); then compound 3.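

In this assay, the change from 2-methoxyphenyl to 2-methoxy-4-methylphenyl gives a 2.0-fold lower number from compound 1 to compound 4 (0.30 log units; within the scatter), and this is the only listed step on this ring, since the earlier step touched the carbonyl carbon. It shows that a methyl on this aromatic carbon, meta to a methoxy group and para to a large group, does not move the number beyond the scatter of the assay. No measurement at hand gives a reason for this result.

The compounds shown leave open whether a larger or different group at this place, such as an ethyl, a primary amine or a carboxylic acid, would shift the number beyond the scatter. They also leave open whether the same methyl would behave alike with the cyclopropyl carbonyl of compound 2.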